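A new group on the sulfonyl sulfur

A few compounds are considered here, and "the series" means these few. Any claim that something is new, unique, unknown or untested is made for them only; others in the source may bear on it.

Compound 1 `CC1CCN(C2CCN(S(=O)(=O)c3cccc(C(F)(F)F)c3)CC2)CC1`: > 5000 nM
Compound 2 `CC1CCN(C2CCN(S(=O)(=O)c3nccn3C)CC2)CC1`: > 10000 nM

Both compounds were tested in an ADME assay on HCT-116 cells (Homo sapiens) for cytotoxicity, read by CellTiter-Glo, with a stated time of 72 h; a lower number here means a stronger inhibitor, a higher number a weaker inhibitor. Compound 2 stands at > 10000 nM, which is a limit of the assay and not a number. Compound 1 gives > 5000 nM, which is also a limit. For the measured compounds named here, no measured step therefore connects related compounds in this assay.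

Compound 3 `COc1cccc(S(=O)(=O)N2CCC(N3CCC(C)CC3)CC2)c1` has not yet been measured. It carries 3-methoxyphenyl in place of 1-methyl-1H-imidazol-2-yl on a sulfonyl sulfur. The expected step, a number no higher from compound 2 to compound 3 (the limit leaves the size open), is none beyond the scatter, and no direction is favoured. This expectation rests on compound 1, whose > 5000 nM is a limit as well, so compound 3 may also be reported only as a limit. For compound 3 the estimate is 10000 nM, with an expected range from 4000 nM to 25000 nM.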

Compound 3, half-maximal inhibitory concentration: > 5000 nM
Compound 3: a limit, no number; the forecaster's own chance of this, stated with the estimate: 75%; the middle value does not contradict the limit.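

For the compounds shown here, compound 3, like compound 1 and compound 2, is reported only as a limit, so no step from compound 2 to compound 3 or from compound 1 to compound 3 can be read. The compounds shown leave open whether the group on the sulfonyl sulfur changes the value at all.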